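Swapping an Aromatic Ring for an Ethyl Chain

The compounds below may be only part of what the source reports. "The series", "measured", "known", "first", "only" and "open" are said of these compounds alone.

Compound 1 `CCc1nncn1-c1ccc(OCc2ccccc2F)cc1` and compound 2 `CCc1nncn1-c1ccc(OCc2ccccc2Cl)cc1` share one core and differ only in a halogen on an aromatic carbon. In a functional assay on the whole organism (strain C57B/6) with Mus musculus as the target, in the maximal electroshock model (a higher number here means that more compound is needed for the effect, a lower number that less compound is needed), compound 1 gives 21.2 mg/kg and compound 2 gives 13.2 mg/kg, a 1.6-fold lower number from compound 1 to compound 2 (0.21 log units; within the scatter). Among the compounds with values here, compound 2 is thus one of only two compounds measured, and its number sits within the scatter of that of compound 1. Compound 3 `CCCOc1ccc(-n2cnnc2CC)cc1` carries ethyl in place of 2-chlorophenyl on a saturated chain carbon bound to an oxygen on an aromatic ring. Within the data shown here, no measured step touches this part of the molecule; the change from compound 1 to compound 2 concerns only the halogen and does not bear on it. Without a guide, a step toward a higher number is expected, a 2.3-fold higher number from compound 2 to compound 3 (0.36 log units; beyond the scatter). For compound 3 the estimated value in this assay is 30 mg/kg, with a range from 12 mg/kg to 80 mg/kg.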

Compound 3, dose for half-maximal effect: > 100 mg/kg
Compound 3 gave a limit, no number (the forecaster's own chance of this, stated with the estimate: 10%); at least 3.3-fold (0.52 log units) between middle value and limit.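

In this assay compound 3 gives a limit of the assay and no number: the limit of > 100 mg/kg in this assay, at which 1 of the 3 values shown sits. Even so, ethyl in place of 2-chlorophenyl brings an at least 7.5-fold higher number from compound 2 to compound 3 (0.87 log units; beyond the scatter), and ethyl in place of 2-fluorophenyl brings an at least 4.7-fold higher number from compound 1 to compound 3 (0.67 log units; beyond the scatter). Where the halogen change stayed within the scatter, replacing the whole group on this saturated chain carbon moves the number beyond it.

On these data alone, how far these steps truly reach stays unknown. Also open, as far as these compounds go, is whether the ring or its halogen carries the difference, which a plain phenyl or a cyclohexyl group at this place could separate.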